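The compounds below may be only part of what the source reports. "The series", "measured", "known", "first", "only" and "open" are said of these compounds alone.

Measured compounds:
- compound 1, `ClCc1ccc(Cn2cnc3c(Cl)ncnc32)cc1`; in a functional assay on NCI-H522 cells (Homo sapiens) for cytotoxicity, read by sulforhodamine B assay, with a stated time of 48 h (on this read-out higher numbers stand for weaker inhibition of growth and lower numbers for stronger inhibition of growth), compound 1 gives only a limit, > 100000 nM.
- compound 2, `ClCc1ccc(Cn2cnc3nc(Cl)nc(Cl)c32)cc1`; in this assay compound 2 gives 4570 nM.
- compound 3, `ClCc1ccc(Cn2cnc3c(Cl)nc(Cl)nc32)cc1`; in this assay compound 3 gives 46800 nM.

Compound 4, `ClCc1ccc(Cn2cnc3ncnc(Cl)c32)cc1`, is still to be measured in this assay.

One change is seen twice in the series. From compound 3 to compound 1 it is hydrogen in place of chloro on an aromatic carbon, and it gave an at least 2.1-fold higher number from compound 3 to compound 1 (0.32 log units; beyond the scatter); the size of that step is bounded by the limit of > 100000 nM in this assay, at which 1 of the 3 values shown sits, so only its lower bound is known. Of the two measured cores, compound 2 sits lowest; the difference between the cores of compound 2 and compound 3 is not broken down here.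

From compound 2 to compound 4 the change is hydrogen in place of chloro on an aromatic carbon. Its place reads word for word as for the earlier pair, so it is the same change. The step is therefore expected to go the same way, as a 4.4-fold higher number from compound 2 to compound 4 (0.64 log units; beyond the scatter), resting on an at least 2.1-fold higher number from compound 3 to compound 1 (0.32 log units; beyond the scatter); its exact size is uncertain, since the earlier step is only a lower bound. Compound 4 is expected to give about 20000 nM, within 6000 nM to 80000 nM.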

Compound 4, concentration for total growth inhibition: > 100000 nM
Compound 4 ended at the assay's limit; the forecaster's own chance of this, stated with the estimate: 20%; middle value at least 5.0-fold (0.69 log units) away from the limit.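

In this assay, hydrogen in place of chloro on an aromatic carbon gives an at least 21-fold higher number from compound 2 to compound 4 (1.34 log units; beyond the scatter), so the change points the same way on the two cores shown: the same change on two cores in this assay, an at least 2.1-fold higher number (0.32 log units; beyond the scatter) from compound 3 to compound 1 and an at least 21-fold higher number (1.34 log units; beyond the scatter) from compound 2 to compound 4; the limit leaves it open whether they differ

Both steps end at a limit of the assay, so each gives only a lower bound, and the true size of neither is known: the limit of > 100000 nM in this assay, at which 2 of the 4 values shown sit.

The direction therefore carries from the core of compound 3 to the core of compound 2, resting on these two pairs alone, but the data do not show that the size carries over, nor that the change counts for more on one core than on the other.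

Still open, as far as these compounds go, is what an amine, a methoxy group or a bromo group on that aromatic carbon would give compared with chloro. The compounds shown also leave open what happens when the chloromethyl group is replaced, for instance by a methyl group, with the chloro groups on the core kept in place.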